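This account rests on a few compounds, and the source may have more. Where it says the series, first, only, none or still open, it means among the compounds named here.

Four related compounds are compared in a functional assay on MCF7 cells (Homo sapiens) for cytotoxicity, read by MTT assay, with a stated time of 72 h; on this read-out higher numbers stand for weaker inhibition and lower numbers for stronger inhibition. Compound 1 `Cc1ccc(-c2ccc(C(=O)Nc3ccc(Oc4ccnc5[nH]ccc45)cc3)nc2)cc1` carries a methyl group on its outer ring, while compound 2 `COc1ccc(-c2ccc(C(=O)Nc3ccc(Oc4ccnc5[nH]ccc45)cc3)nc2)cc1` carries a methoxy group in its place. Compound 3 `Cc1ccc(-c2ccc(C(=O)Nc3ccc(Oc4ccnc5[nH]ccc45)c(F)c3)nc2)cc1` keeps the methyl group of compound 1 but adds a fluoro group to the ring that bears the amide nitrogen, and compound 4 `COc1ccc(-c2ccc(C(=O)Nc3ccc(Oc4ccnc5[nH]ccc45)c(F)c3)nc2)cc1` combines that fluoro group with the methoxy group of compound 2.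

In this assay compound 1 gives only a limit of the assay, > 10000 nM. Compound 2 likewise gives only a limit, > 10000 nM. Among the compounds with values here, compound 3 is the one compound with a number, 8020 nM.

The change from compound 1 to compound 2 is methoxy in place of methyl on an aromatic carbon. The step it made is a step that the two limits leave unreadable from compound 1 to compound 2, and its size cannot be read because of the limit of > 10000 nM in this assay, at which 2 of the 3 values shown sit. The change from compound 1 to compound 3 is fluoro in place of hydrogen on an aromatic carbon, and the step it made is an at least 1.2-fold lower number from compound 1 to compound 3 (0.09 log units; that floor lies within the scatter).

Compound 4 differs from compound 3 by methoxy in place of methyl on an aromatic carbon, the same change as between compound 1 and compound 2. Within the data shown here, the only measured example of this change has both of its ends at the limit, so the data give no size for it. Since compound 3 reaches 8020 nM, a step of about a 1.1-fold higher number from compound 3 to compound 4 (0.05 log units; within the scatter) is expected, with the value of compound 4 expected to lie close to that of compound 3. Compound 4 is therefore estimated at 9000 nM in this assay, most likely between 3000 nM and 30000 nM.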

Compound 4, half-maximal inhibitory concentration: 10100 nM
Compound 4: middle estimate off by 1.1-fold (0.05 log units), on the low side, within the range that was stated.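

In this assay, putting methoxy in place of methyl on the core that carries the fluoro group gives a 1.3-fold higher number from compound 3 to compound 4 (0.10 log units; within the scatter), so on this core compound 3 and compound 4 cannot be told apart. The same change on the core of compound 1 offers nothing to set beside this result, and the fluoro step from compound 2 to compound 4 cannot be read either, because at least one end of each of these steps is only a limit: the limit of > 10000 nM in this assay, at which 2 of the 4 values shown sit. The series therefore gives one readable example of the change from 4-methylphenyl to 4-methoxyphenyl, which shows that the swap made no difference beyond the scatter on one core, but it does not show that the change carries over from one core to the other.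

The compounds shown leave open whether any group in this place on the outer ring could move the number beyond the scatter, since they hold only methyl and methoxy there, and an amine, a carboxylic acid or a longer chain might behave differently. They also leave open what the fluoro group does on either core, since neither of its two steps gives a size beyond the scatter.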